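Swapping the aryl group on the pyridazinone-bearing core

The compounds below may be only part of what the source reports. "The series", "measured", "known", "first", "only" and "open" are said of these compounds alone.

Compound 1 `COc1cc2c(Oc3ccc(NC(=O)c4nn(-c5ccccc5C)c(=O)cc4C)cc3F)ccnc2cc1OCCCN1CCCC1` and compound 2 `COc1cc2c(Oc3ccc(NC(=O)c4nn(-c5ccccc5C)c(=O)cc4C)cc3F)ccnc2cc1OCCCN1CCN(C)CC1` share one core and differ only in the basic ring at the end of the side chain. In a functional assay on MKN-45 cells (Homo sapiens) for inhibition, read by MTT assay, with a stated time of 72 h (a higher number here means a weaker inhibitor, a lower number a stronger inhibitor), compound 1 gives 760 nM, while compound 2 gives 1630 nM. Among the measured compounds shown here, the step of a 2.1-fold higher number from compound 1 to compound 2 (0.33 log units; beyond the scatter) is modest, and compound 2 stands as the higher of the two numbers measured so far. Compound 3 `COc1cc2c(Oc3ccc(NC(=O)c4nn(-c5ccc(Cl)cc5)c(=O)cc4C)cc3F)ccnc2cc1OCCCN1CCN(C)CC1` keeps the side chain of compound 2 and changes the aryl group on the ring nitrogen: 4-chlorophenyl in place of 2-methylphenyl on an aromatic nitrogen. For the measured compounds named here, no measured step touches this aryl group, so nothing in the two numbers says how this change shifts potency. With only the value of compound 2 as an anchor, the expected step of a 1.6-fold lower number from compound 2 to compound 3 (0.21 log units; within the scatter) is set at none beyond the scatter. Compound 3 is therefore estimated at 1000 nM, with a wide range from 250 nM to 4000 nM.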

Compound 3, half-maximal inhibitory concentration: 40 nM
Compound 3: the middle estimate sits 25-fold (1.40 log units) above what was measured; measured number outside the range, below it.
By their numbers in this assay, from the lowest: compound 3; then compound 1; then compound 2.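

In this assay, the aryl group on the aromatic nitrogen proves a far stronger lever than the ring at the end of the side chain: 4-chlorophenyl in place of 2-methylphenyl gives a 41-fold lower number from compound 2 to compound 3 (1.61 log units; beyond the scatter), whereas the side-chain swap gives only a 2.1-fold higher number from compound 1 to compound 2 (0.33 log units; beyond the scatter). The two aryl groups match in heavy atoms, ring type, hydrogen-bond counts and charge, so a large shift in potency can arise here without any change in those counts. Nothing measured here explains why this swap has such a large effect.

Going by these compounds, this single change both removes the methyl group and adds the chlorine at a different ring position, so the contribution of each remains open. A 4-methylphenyl or 2-chlorophenyl group on the same nitrogen would help separate the two.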